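This account rests on a few compounds, and the source may have more. Where it says the series, first, only, none or still open, it means among the compounds named here.

Compound 1 `OC[C@H]1O[C@@H](n2cnc3c(NCc4cccc(Br)c4)ncnc32)[C@H](O)[C@@H]1O` carries a 3-bromophenyl group on the saturated chain carbon bound to a nitrogen of the shared core. In a functional assay on K562 cells (Homo sapiens) for antiproliferative activity, with a stated time of 72 h (a higher number here means a weaker inhibitor, a lower number a stronger inhibitor), compound 1 gives 19700 nM, and this is the only numerical result among the three measured compounds. Compound 2 `Cc1cccc(CNc2ncnc3c2ncn3[C@@H]2O[C@H](CO)[C@@H](O)[C@H]2O)c1` reaches only a limit of this assay, > 166000 nM. Compound 3 `Cc1ccc(CNc2ncnc3c2ncn3[C@@H]2O[C@H](CO)[C@@H](O)[C@H]2O)cc1` likewise reaches only a limit, > 166000 nM. Thus an at least 8.4-fold higher number from compound 1 to compound 2 (0.92 log units; beyond the scatter) and an at least 8.4-fold higher number from compound 1 to compound 3 (0.92 log units; beyond the scatter), both reflecting (the limit of > 166000 nM in this assay, at which 2 of the 3 values shown sit). The step between compound 2 and compound 3 cannot be read because a step that the two limits leave unreadable from compound 2 to compound 3.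

Compound 4 `COc1cccc(CNc2ncnc3c2ncn3[C@@H]2O[C@H](CO)[C@@H](O)[C@H]2O)c1O` differs from compound 1 as follows: 2-hydroxy-3-methoxyphenyl in place of 3-bromophenyl on a saturated chain carbon bound to a nitrogen on an aromatic ring. Both measured changes of the 3-bromophenyl group gave a weaker inhibitor, so a weakening step is expected here too, of a size that probably reaches the limit. Compound 4 is therefore expected to give 150000 nM, within a range from 40000 nM to 500000 nM. The estimated step of a 7.6-fold higher number from compound 1 to compound 4 (0.88 log units; beyond the scatter) is expected to be a clear loss.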

Compound 4, half-maximal inhibitory concentration: 27900 nM
Compound 4: the middle estimate sits 5.4-fold (0.73 log units) above what was measured, outside the stated range (below it).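

In this assay, replacing 3-bromophenyl with 2-hydroxy-3-methoxyphenyl on the saturated chain carbon leaves no readable difference, with a 1.4-fold higher number from compound 1 to compound 4 (0.15 log units; within the scatter), so a measurable number at this place is not confined to the bromine compound. The two methylphenyl compounds stand clearly apart from the new compound, with an at least 5.9-fold lower number from compound 3 to compound 4 (0.77 log units; beyond the scatter) and an at least 5.9-fold lower number from compound 2 to compound 4 (0.77 log units; beyond the scatter). These last two steps give only minimum sizes, since each starts from a limit rather than a number: the limit of > 166000 nM in this assay, at which 2 of the 4 values shown sit.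

On these data alone, it remains open whether the hydroxy group, the methoxy group or the two together account for the gap from the methylphenyl compounds. Also open, as far as these compounds go, is how a phenyl ring carrying an amine or a carboxylic acid would behave at this place.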